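Sulfonamide series: working notes on cytotoxicity

The source may hold more compounds than are shown below. What is called first, only, known or untested is meant among the compounds shown, and "the series" means these compounds.

Compound 1 `O=S(=O)(Nc1ccc2oc(-c3ccccc3)nc2c1)c1ccccc1O`: 33000 nM in an ADME assay on HEK293 cells (Homo sapiens) for cytotoxicity, read by resazurin assay, with a stated time of 48 h; on this read-out lower numbers stand for higher toxicity in this test and higher numbers for lower toxicity in this test.
Compound 2 `COc1ccc(S(=O)(=O)Nc2ccc(-c3nc4ccccc4o3)cc2)cc1`: only the limit > 100000 nM in this assay.
Compound 3 `O=S(=O)(Nc1ccc(-c2nc3ccccc3o2)cc1)c1ccccc1C(F)(F)F`: only the limit > 100000 nM in this assay.

Compound 2 stands at the assay limit, not at a number, and shares that position with one other compound, (the limit of > 100000 nM in this assay, at which 2 of the 3 values shown sit). Among the compounds with values here, compound 1 is the single compound with a measured number. Compound 4 `COc1ccc(Cl)cc1S(=O)(=O)Nc1ccc(-c2nc3ccccc3o2)cc1` differs from compound 2 by 5-chloro-2-methoxyphenyl in place of 4-methoxyphenyl on a sulfonyl sulfur. Within the data shown here, no measured pair in this set shows a single change, so no step size is known. The step from compound 2 to compound 4 is expected to stay within scatter, a number no higher from compound 2 to compound 4 (the limit leaves the size open), so compound 4 is expected to give 100000 nM, between 30000 nM and 300000 nM, most likely again as a limit.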

Compound 4, half-maximal cytotoxic concentration: 75000 nM
Beside the measured number, compound 4's estimate is 1.3-fold (0.12 log units) above it; measured number inside the range.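

In this assay, within the data shown here, 5-chloro-2-methoxyphenyl in place of 4-methoxyphenyl on a sulfonyl sulfur gives an at least 1.3-fold lower number from compound 2 to compound 4 (0.12 log units; that floor lies within the scatter), the first step that can be read. The true size of the step stays open because compound 2 is held only as a limit: the limit of > 100000 nM in this assay, at which 2 of the 4 values shown sit.

The compounds shown leave open whether the chlorine or the changed place of the methoxy group carries this step. They also leave open how an aminophenyl or a carboxyphenyl group on the sulfonyl sulfur would read in this assay.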